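This account rests on a few compounds, and the source may have more. Where it says the series, first, only, none or still open, it means among the compounds named here.

Measured in a functional assay on HCT-116 cells (Homo sapiens) for inhibition, read by CCK-8 assay, with a stated time of 48 h; on this read-out higher numbers stand for weaker inhibition and lower numbers for stronger inhibition:
- Compound 1 `COc1cc(-c2ccnc3cc(-c4c[nH]c5ccccc45)nn23)cc(OC)c1OC`: 35 nM
- Compound 2 `COc1cc(-c2ccnc3cc(-c4ccc5c(ccn5C)c4)nn23)cc(OC)c1OC`: 39 nM
- Compound 3 `COc1cc(-c2ccnc3cc(-c4cccc(C)c4)nn23)cc(OC)c1OC`: 6150 nM

Compound 3 has the highest number of the three and is the weakest inhibitor here. Compound 4 `COc1ccc(-c2cc3nccc(-c4cc(OC)c(OC)c(OC)c4)n3n2)cc1F` differs from it at one place: 3-fluoro-4-methoxyphenyl in place of 3-methylphenyl on an aromatic carbon.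

Two measured steps at this place are large: a 180-fold higher number from compound 1 to compound 3 (2.24 log units; beyond the scatter) and a 160-fold higher number from compound 2 to compound 3 (2.20 log units; beyond the scatter). The remaining step, between the 1H-indol-3-yl and 1-methyl-1H-indol-5-yl groups, is a 1.1-fold higher number from compound 1 to compound 2 (0.05 log units; within the scatter). The number in this assay therefore responds strongly to the group at this place. However, both low numbers belong to indolyl compounds, whereas compound 4 keeps one six-membered aromatic ring of carbon only, as compound 3 does. For the measured compounds named here, no measured step isolates the effect of a fluorine or methoxy group on such a ring. A move towards stronger inhibition is expected, but smaller than the two large steps and uncertain in size. The expected step is a 7.7-fold lower number from compound 3 to compound 4 (0.89 log units; beyond the scatter). For compound 4 the estimated value is 800 nM, with an expected range of 90 nM to 6000 nM.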

Compound 4, half-maximal inhibitory concentration: 2840 nM
For compound 4 the middle estimate is 3.6-fold (0.55 log units) below the measured one; measured number inside the range.
By their numbers in this assay, from the lowest: compounds 1 and 2 (each within the scatter of the next); then compound 4; then compound 3.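

In this assay the change from 3-methylphenyl to 3-fluoro-4-methoxyphenyl gives only a modest gain (a 2.2-fold lower number from compound 3 to compound 4 (0.34 log units; beyond the scatter)), so this position also separates two groups that each keep one six-membered aromatic ring of carbon only. That gain leaves compound 4 far from the indolyl compounds (a 73-fold higher number from compound 2 to compound 4 (1.86 log units; beyond the scatter)) and (an 81-fold higher number from compound 1 to compound 4 (1.91 log units; beyond the scatter)), so the fluoro and methoxy groups on this ring do not close the gap to either indolyl compound. No measured evidence on the cause of these steps is available.

The change swaps methyl for fluoro and methoxy together, so the share of each group in the step cannot be read. From the compounds shown here alone, it also remains open where a pyridin-3-yl ring, or a phenyl ring carrying an amine, would fall relative to the indolyl compounds and compound 4.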